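Removing a Methoxy Group Across Two Amide Cores

This account rests on a few compounds, and the source may have more. Where it says the series, first, only, none or still open, it means among the compounds named here.

Compound 1 `O=C(Nc1ccccc1)c1cccc(Br)c1` and compound 2 `COc1ccc(Br)cc1C(=O)Nc1ccccc1` share one core, while compound 3 `COc1ccccc1C(=O)Nc1ccc(Sc2nc3ccccc3s2)cc1` carries another; the difference between the two cores is not broken down here. In an assay for inhibition of HSP60/HSP10 (Homo sapiens), with a stated time of 60 min (a higher number here means a weaker inhibitor, a lower number a stronger inhibitor), compound 1 gives > 100000 nM, which is a limit of the assay. Compound 2 gives > 100000 nM in this assay, again a limit. Compound 3 gives > 100000 nM in this assay, also a limit. The change hydrogen in place of methoxy on an aromatic carbon thus yields a step that the two limits leave unreadable from compound 2 to compound 1. Compound 4 `O=C(Nc1ccc(Sc2nc3ccccc3s2)cc1)c1ccccc1` arises from compound 3 by the same kind of change, (hydrogen in place of methoxy on an aromatic carbon), though here the place is ortho to a large group rather than ortho to a group of 9 heavy atoms and para to a bromo group. Given (the limit of > 100000 nM in this assay, at which 3 of the 3 values shown sit), compound 4 is expected to show a step that the limit leaves unreadable from compound 3 to compound 4. Compound 4 is estimated at 150000 nM, between 50000 nM and 600000 nM.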

Compound 4, half-maximal inhibitory concentration: > 100000 nM
Compound 4 gave a limit, no number (the forecaster's own chance of this, stated with the estimate: 85%); the middle value is on the limit's open side.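

No new step can be read between compound 3 and compound 4, as both give only a limit: the limit of > 100000 nM in this assay, at which 4 of the 4 values shown sit. The compounds shown leave open what the change from 2-methoxyphenyl to phenyl does in this assay.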